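Methyl in Place of Methoxy: What Step to Expect

The compounds below may be only part of what the source reports. "The series", "measured", "known", "first", "only" and "open" are said of these compounds alone.

Compound 2 `COc1cc(OC(F)(F)F)ccc1Nc1nc2nonc2nc1O` has been measured in an assay on mitochondria from L6 cells (Rattus norvegicus) for activation, with a stated time of 90 min (on this read-out higher numbers stand for an effect only at larger amounts of compound and lower numbers for an effect already at smaller amounts), where compound 2 gives 3800 nM. Of the two numbers shown it stands highest; its nearest neighbour is compound 1 `Oc1nc2nonc2nc1Nc1ccc(OC(F)(F)F)cc1Cl`, which in this assay gives 1400 nM. Among the measured compounds shown here, the one measured step, a 2.7-fold higher number from compound 1 to compound 2 (0.43 log units; beyond the scatter), lies beyond the scatter and is described as modest. Compound 3 `Cc1cc(OC(F)(F)F)ccc1Nc1nc2nonc2nc1O` has not yet been measured; it differs from compound 2 by methyl in place of methoxy on an aromatic carbon. For the measured compounds named here, only that single step bears on the new change, and it went toward a higher number when chloro gave way to methoxy. Since methyl is neither chloro nor methoxy, compound 3 is expected to fall between the two measured compounds, the step of a 1.7-fold lower number from compound 2 to compound 3 (0.24 log units; within the scatter) pointing toward a lower number. In this assay compound 3 is therefore estimated at 2200 nM, with a likely range from 800 nM to 6000 nM.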

Compound 3, half-maximal effective concentration: 4600 nM
Compound 3: middle estimate off by 2.1-fold (0.32 log units), on the low side; measured number inside the range.
By their numbers in this assay, from the lowest: compound 1; then compounds 2 and 3 (each within the scatter of the next).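

In this assay, methyl in place of methoxy on this aromatic carbon, ortho to a large group, gives a 1.2-fold higher number from compound 2 to compound 3 (0.08 log units; within the scatter) and so leaves compound 2 and compound 3 inseparable on this read-out, although one heavy atom and the hydrogen-bond acceptor of methoxy are gone. Chloro now stands apart from both other groups, for beside the earlier step there is a 3.3-fold higher number from compound 1 to compound 3 (0.52 log units; beyond the scatter) and compound 1 alone has steps to all others printed as beyond the scatter. Nothing measured here explains why chloro differs from methoxy and methyl at this place.

Going by these compounds, whether fluoro, bromo, ethyl or an amine at this place would match chloro or match methoxy and methyl stays open. So does whether the gap between chloro and the other two groups holds when the trifluoromethoxy group is replaced.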